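The source may report more compounds than this note shows. Statements on the series, on what has been measured and on what is new or still open speak of the compounds shown alone.

All readings in these notes come from a functional assay on U-373MG ATCC cells (Homo sapiens) for inhibition, read by colorimetric assay and MTT assay, with a stated time of 72 h; on this read-out lower numbers stand for stronger inhibition and higher numbers for weaker inhibition. Compound 1 (`C=CCCCCOc1ccccc1-c1cnc(OCCCCC=C)n1C`) gives 7000 nM. For compound 2 (`CCCCCCOc1ncc(-c2ccccc2OC)n1C`) the entry reads "not determined" (no result reported), so it offers no number for comparison. Compound 3 (`C=CCCOc1ncc(-c2ccccc2OC)n1C`) gives 16000 nM, the higher of the two available numbers, and compound 1 lies below it by more than the usual scatter of repeat measurements.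

Compound 4 (`C=CCCCCOc1ncc(-c2ccccc2OC)n1C`) has not yet been measured. Its difference from compound 3 is but-3-en-1-yl in place of vinyl on a saturated chain carbon, two bonds along the chain from an oxygen on an aromatic ring. Cut one bond further out, the same difference reads (but-3-en-1-yl)oxy to (hex-5-en-1-yl)oxy. For the measured compounds named here, no measured pair isolates this change, so its size cannot be read directly. Going by the values given here, compound 4 differs elsewhere in its structure from compound 1, the only indirect guide, which also carries a (hex-5-en-1-yl)oxy group and gives 7000 nM. On that single reading, the number is expected to fall modestly rather than rise. The estimated change is a 1.8-fold lower number from compound 3 to compound 4 (0.25 log units; within the scatter), a small step toward stronger inhibition that may not clear the scatter. For compound 4 the estimate is 9000 nM, with an expected range of 4500 nM to 18000 nM.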

Compound 4, half-maximal inhibitory concentration: 9000 nM
Estimate against measurement, compound 4: no gap at the digits printed, within the range that was stated.
By their numbers in this assay, from the lowest: compounds 1, 4 and 3 (each within the scatter of the next, the first and the last beyond it).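

In this assay, for the compounds shown here, the swap of (but-3-en-1-yl)oxy for (hex-5-en-1-yl)oxy on the shared core gives a 1.8-fold lower number from compound 3 to compound 4 (0.25 log units; within the scatter) and so gives the first direct reading at this position: the two added chain carbons do not separate these compounds beyond the scatter. At the other place, hydrogen in place of pent-4-en-1-yl on a saturated chain carbon bound to an oxygen on an aromatic ring gives a 1.3-fold higher number from compound 1 to compound 4 (0.11 log units; within the scatter) and so also stays within the scatter, which means that neither single change shown here resolves a difference in this series. No independent evidence bears on why either step is this size.

As far as these compounds go, compound 2 carries no number, so its steps cannot be read, and the effect of the terminal double bond on this chain remains open. Also open, from the compounds shown here alone, is whether a longer chain than hex-5-en-1-yl, or a chain ending in an amine or a carboxylic acid, on this oxygen would move the number beyond the scatter.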